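The compounds below may be only part of what the source reports. "The series", "measured", "known", "first", "only" and "open" are said of these compounds alone.

Four compounds share one core and differ only in the group on the amine nitrogen. Compound 1 `COc1cc(Oc2cccc(Nc3ccccc3)c2)cc(OC)c1CNC1CC1` carries cyclopropyl there. In a functional assay on HCT-116 cells (Homo sapiens) for inhibition, read by MTT assay, with a stated time of 72 h (on this read-out lower numbers stand for stronger inhibition and higher numbers for weaker inhibition), compound 1 reaches only the assay limit > 20000 nM. Compound 2 `COc1cc(Oc2cccc(Nc3ccccc3)c2)cc(OC)c1CNCCNC(C)=O` carries 2-acetamidoethyl, and in this assay compound 2 gives 18200 nM, the higher of the two full numbers. Compound 3 `COc1cc(Oc2cccc(Nc3ccccc3)c2)cc(OC)c1CNCc1ccccc1` carries benzyl, and in this assay compound 3 gives 4070 nM. The step of a 4.5-fold lower number from compound 2 to compound 3 (0.65 log units; beyond the scatter) is the nearest comparison. Compound 4 `COc1cc(Oc2cccc(Nc3ccccc3)c2)cc(OC)c1CNCc1ccc(O)cc1` is not yet measured; it differs from compound 2 by 4-hydroxyphenyl in place of acetamidomethyl on a saturated chain carbon bound to an amine nitrogen. Since the closest measured step was a 4.5-fold lower number from compound 2 to compound 3 (0.65 log units; beyond the scatter), and an at least 4.9-fold lower number from compound 1 to compound 3 (0.69 log units; beyond the scatter) points the same way, a similar lowering is expected, so compound 4 is estimated at 4200 nM, likely between 1500 nM and 12000 nM, an expected step of a 4.3-fold lower number from compound 2 to compound 4 (0.64 log units; beyond the scatter).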

Compound 4, half-maximal inhibitory concentration: 3360 nM
Estimate against measurement, compound 4: 1.3-fold (0.10 log units) above; low and high end bracket the measured number.
By their numbers in this assay, from the lowest: compounds 4 and 3 (each within the scatter of the next); then compound 2. At a limit, above all of these: compound 1.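

The step of a 1.2-fold lower number from compound 3 to compound 4 (0.08 log units; within the scatter) lies within the scatter, so in this assay hydroxy in place of hydrogen on an aromatic carbon brings no readable difference. The 4-hydroxybenzyl group still keeps the advantage over 2-acetamidoethyl, with a 5.4-fold lower number from compound 2 to compound 4 (0.73 log units; beyond the scatter). Against compound 1 the step of an at least 5.9-fold lower number from compound 1 to compound 4 (0.77 log units; beyond the scatter) is only a floor, since compound 1 stands at a limit: the limit of > 20000 nM in this assay, at which 1 of the 4 values shown sits.

Still open, as far as these compounds go, is how an amine or a carboxylic acid in place of the hydroxy would read in this assay. From the compounds shown here alone, a longer chain carrying the aromatic ring is equally open.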